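A few compounds are considered here, and "the series" means these few. Any claim that something is new, unique, unknown or untested is made for them only; others in the source may bear on it.

For the measured compounds named here, in an assay on CHO cells for displacement of a labelled ligand from corticotropin-releasing factor receptor 1 (Homo sapiens) (a lower number here means a stronger inhibitor, a higher number a weaker inhibitor), compound 2 `CCCCN(CCCC)c1nc2c(c(-c3c(C)cc(C)cc3C)cn2C)c(=O)n1C` gives 970 nM, the highest of the two numbers measured so far. Compound 1 `CCCN(CCC)c1nc2c(c(-c3c(C)cc(C)cc3C)cn2C)c(=O)n1C` gives 120 nM in this assay. Compound 3 `Cc1cc(C)c(-c2cn(C)c3nc(N(CC4CC4)CC4CC4)n(C)c(=O)c23)c(C)c1` carries bis(cyclopropylmethyl)amino in place of dibutylamino on an aromatic carbon. Going by the values given here, the only measured step that bears on this change is an 8.1-fold higher number from compound 1 to compound 2 (0.91 log units; beyond the scatter), in which longer chains on the same nitrogen gave a weaker inhibitor. The entering group instead closes each chain into a three-membered ring, so compound 3 is expected to land nearer compound 1 than compound 2. Compound 3 is therefore estimated at 250 nM, within 80 nM to 800 nM, a step of a 3.9-fold lower number from compound 2 to compound 3 (0.59 log units; beyond the scatter).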

Compound 3, half-maximal inhibitory concentration: 140 nM
Compound 3: the middle estimate sits 1.8-fold (0.25 log units) above what was measured, and the stated range covers the measured number.
By their numbers in this assay, from the lowest: compounds 1 and 3 (each within the scatter of the next); then compound 2.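

In this assay the swap from dibutylamino to bis(cyclopropylmethyl)amino keeps the same count of heavy atoms yet gives a 6.9-fold lower number from compound 2 to compound 3 (0.84 log units; beyond the scatter) and so shows that the number at this position does not follow that count alone. The step of a 1.2-fold higher number from compound 1 to compound 3 (0.07 log units; within the scatter) lies within the scatter, so the dipropylamino and bis(cyclopropylmethyl)amino groups cannot be told apart here. Nothing measured on these compounds offers a reason for these steps.

Still open, as far as these compounds go, is how a shorter diethylamino group or a morpholine ring would compare at this position. Also open, from the compounds shown here alone, is whether bis(cyclobutylmethyl)amino, with larger rings, would sit with compound 3 or with compound 2.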